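The compounds below may be only part of what the source reports. "The series", "measured", "known", "first", "only" and "open" are said of these compounds alone.

Compound 1 `CC(=O)OC[C@H]1O[C@@H](S[C@H]2CC(=O)[C@@H]3OC[C@H]2O3)[C@H](OC(C)=O)[C@@H](OC(C)=O)[C@@H]1OC(C)=O`: 119000 nM
Compound 2 `O=C1C[C@H](S[C@@H]2O[C@H](CO)[C@@H](O)[C@H](O)[C@H]2O)[C@H]2CO[C@@H]1O2`: 692000 nM

In a functional assay on A549 cells (Homo sapiens) for cytotoxicity, read by CCK-8 assay, with a stated time of 14 h (a higher number here means a weaker inhibitor, a lower number a stronger inhibitor), compound 1 gives 119000 nM, the lower of the two numbers, and compound 2 gives 692000 nM. That gap lies beyond the usual scatter. Compound 3 `CC(=O)OC[C@H]1O[C@@H](S[C@H]2CC(=O)[C@@H]3OC[C@H]2O3)[C@H](OC(C)=O)[C@@H](OC(C)=O)[C@H]1OC(C)=O` is the close relative of compound 1 still awaiting measurement: the two compounds have the same atoms and bonds and differ only in configuration as drawn: 1 of 8 stereo elements differ; a stereocentre at a saturated ring carbon is drawn R in compound 1 and S in compound 3. Going by the values given here, no measured pair here differs at a single stereocentre, so the data give no direct guide to the size or direction of such a change. With nothing to favour either direction, no step beyond the scatter is expected in this assay, and the expectation stays anchored on compound 1 at 119000 nM. The estimated change is small: a 1.1-fold higher number from compound 1 to compound 3 (0.04 log units; within the scatter). For compound 3 the expected value is 130000 nM, with an estimated range of 50000 nM to 320000 nM.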

Compound 3, half-maximal inhibitory concentration in the A549 assay: 467000 nM
Compound 3: the middle estimate sits 3.6-fold (0.56 log units) below what was measured; the whole stated range lies below it.
By their numbers in the A549 assay, from the lowest: compound 1; then compounds 3 and 2 (each within the scatter of the next).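

This gives a direct reading of a single stereocentre at a saturated ring carbon, which the earlier pair could not provide: in the A549 assay, compound 1 gives 119000 nM and compound 3 gives 467000 nM, so turning it from R to S gives a 3.9-fold higher number from compound 1 to compound 3 (0.59 log units; beyond the scatter). In a physicochemical assay for lipophilicity (on this read-out lower numbers stand for lower lipophilicity and higher numbers for higher lipophilicity), compound 1 gives -1.13 and compound 3 gives -1.13; the same change gives no change at the digits printed from compound 1 to compound 3 (within the scatter), so the partition coefficient does not separate the pair. The gap in the cell read-out can be assigned to stereochemistry alone because no atom or bond changes: the fact that compounds 1 and 3 differ only in the configuration as drawn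

Going by these compounds, whether the other seven stereo elements are equally sensitive, and whether this step would persist with the free hydroxyl groups of compound 2, remains open. The compounds shown also leave open what an amine or a carboxylic acid at this carbon would do in the A549 assay.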